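This account rests on a few compounds, and the source may have more. Where it says the series, first, only, none or still open, it means among the compounds named here.

Of the compounds shown here, three sharing one core have been measured in a functional assay on HT-1080 cells (Homo sapiens) for cytotoxicity, read by MTT assay, with a stated time of 72 h; a higher number here means a weaker inhibitor, a lower number a stronger inhibitor. Compound 1 `COc1cccc(/C=C2\CCC/C(=C\c3cc(Cl)cc(Cl)c3)C2=O)c1OC` gives 6100 nM. Compound 2 `COc1cc(/C=C2\CCC/C(=C\c3cccc(OC)c3OC)C2=O)ccc1O` gives 5900 nM. Compound 3 `COc1ccc(/C=C2\CCC/C(=C\c3ccc(Br)cc3)C2=O)cc1OC` gives 4300 nM. The number of compound 3 sits at the lower end of the three, yet its gaps to compound 2 and to compound 1 both lie within the usual scatter, so none of the three is set apart from the others. For the measured compounds named here, the only step between measured compounds that differ in one place is a 1.0-fold lower number from compound 1 to compound 2 (0.01 log units; within the scatter), where 4-hydroxy-3-methoxyphenyl took the place of 3,5-dichlorophenyl on a double-bonded chain carbon bound to a double-bonded ring carbon.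

Compound 4 `COc1cc(/C=C2\CCC/C(=C\c3ccc(OC)c(OC)c3)C2=O)ccc1O` has not yet been measured. It differs from compound 3 by 4-hydroxy-3-methoxyphenyl in place of 4-bromophenyl on a double-bonded chain carbon bound to a double-bonded ring carbon. The same group enters at the same place as in that measured step, which stayed within the scatter, so a step of no more than the scatter is expected in this assay, in either direction. For compound 4 the expected step is a 1.1-fold higher number from compound 3 to compound 4 (0.05 log units; within the scatter). Compound 4 is estimated at 4800 nM, with a range from 2400 nM to 9500 nM.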

Compound 4, half-maximal inhibitory concentration: 4600 nM
The estimate for compound 4 lay 1.0-fold (0.02 log units) above the measured number; low and high end bracket the measured number.
By their numbers in this assay, from the lowest: compounds 3, 4, 2 and 1 (each within the scatter of the next).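

In this assay, 4-hydroxy-3-methoxyphenyl in place of 4-bromophenyl on a double-bonded chain carbon bound to a double-bonded ring carbon gave a 1.1-fold higher number from compound 3 to compound 4 (0.03 log units; within the scatter). With the earlier exchange of 3,5-dichlorophenyl for the same group, which gave a 1.0-fold lower number from compound 1 to compound 2 (0.01 log units; within the scatter), this group has now entered at this place against two different halogen-bearing phenyl groups, and neither step went beyond the scatter, even though the entering group brings 1 hydrogen-bond donor and 2 hydrogen-bond acceptors where 4-bromophenyl has none. No measurement at hand offers an explanation for this result.

All the groups shown at this place are substituted phenyl rings. On these data alone, whether an amine, a carboxylic acid or a longer chain there would give a step beyond the scatter remains open.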